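Phenyl in place of pyridin-3-yl on the carbonyl

This account rests on a few compounds, and the source may have more. Where it says the series, first, only, none or still open, it means among the compounds named here.

In an in vitro ADME assay on microsomes from liver (Homo sapiens) for metabolic stability (a lower number here means slower removal, a higher number faster removal of the compound), compound 3 (`CC(C)NC(=O)[C@H]1CC[C@@H](n2/c(=N/C(=O)c3cccnc3)[nH]c3ccc(CN4CCC(C(C)(C)O)CC4)cc32)CC1`) gives 47 mL.min-1.g-1. Compound 2 (`CC(C)NC(=O)[C@H]1CC[C@@H](n2/c(=N/C(=O)c3ccncc3)[nH]c3ccc(CN4CCC(C(C)(C)O)CC4)cc32)CC1`) gives 57 mL.min-1.g-1, and these two values sit within the scatter of each other. Compound 1 (`CC(C)NC(=O)[C@H]1CC[C@@H](n2/c(=N/C(=O)c3ccccc3)[nH]c3ccc(CN4CCCCC4)cc32)CC1`) gives 203 mL.min-1.g-1, a higher number than either.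

The next structure is compound 4 (`CC(C)NC(=O)[C@H]1CC[C@@H](n2/c(=N/C(=O)c3ccccc3)[nH]c3ccc(CN4CCC(C(C)(C)O)CC4)cc32)CC1`), with phenyl in place of pyridin-3-yl on a carbonyl carbon. Going by the values given here, the only measured step at this carbonyl is a 1.2-fold lower number from compound 2 to compound 3 (0.08 log units; within the scatter). It exchanges pyridin-4-yl for pyridin-3-yl and stays within the scatter, but it never removes the ring nitrogen, so it bears on the new change only indirectly. Compound 1, at 203 mL.min-1.g-1, also carries phenyl there but differs elsewhere in the structure, so it gives only a weak hint of a higher number.

A small upward move is expected in this assay, not clearly beyond the scatter: a 1.4-fold higher number from compound 3 to compound 4 (0.14 log units; within the scatter). For compound 4 the estimate is 65 mL.min-1.g-1, with an expected range of 35 mL.min-1.g-1 to 130 mL.min-1.g-1.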

Compound 4, intrinsic clearance in microsomes: 40 mL.min-1.g-1
Compound 4: the middle estimate sits 1.6-fold (0.21 log units) above what was measured, and the stated range covers the measured number.
By their numbers in this assay, from the lowest: compounds 4, 3 and 2 (each within the scatter of the next); then compound 1.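

In this assay, the ring nitrogen of this acyl group makes no readable difference: both a 1.2-fold lower number from compound 3 to compound 4 (0.07 log units; within the scatter) and a 1.4-fold lower number from compound 2 to compound 4 (0.15 log units; within the scatter) stay within the scatter, so phenyl, pyridin-3-yl and pyridin-4-yl on a carbonyl carbon cannot be told apart while the 1-hydroxy-1-methylethyl group is present. Phenyl on the carbonyl therefore does not by itself carry the high number of compound 1, since a 5.1-fold lower number from compound 1 to compound 4 (0.71 log units; beyond the scatter) lies beyond the scatter with 1-hydroxy-1-methylethyl in place of hydrogen on a saturated ring carbon as the one difference. No measurement at hand explains either result.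

From the compounds shown here alone, whether this flat response at the carbonyl extends to a saturated cyclohexyl group remains open. Also open, going by these compounds, is whether a carboxylic acid or a methoxy group on that saturated ring carbon would match 1-hydroxy-1-methylethyl.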